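Compound 2 to compound 4 at the assay limit

A few compounds are considered here, and "the series" means these few. Any claim that something is new, unique, unknown or untested is made for them only; others in the source may bear on it.

In an ADME assay on HFF cells (Homo sapiens) for cytotoxicity, with a stated time of 8 days (a lower number here means that less compound is tolerated, a higher number that more compound is tolerated), compound 2 `C=CCOc1nc(N)nc2c1ncn2/C=C1/CC1(CO)CO` gives > 300000 nM which is a limit of the assay and not a number. Compound 1 `Nc1nc(OCC(F)(F)F)c2ncn(/C=C3/CC3(CO)CO)c2n1` gives > 300000 nM which is also a limit. Compound 3 `Nc1nc(OCc2ccccc2)c2ncn(/C=C3/CC3(CO)CO)c2n1` gives > 300000 nM which is again a limit. Going by the values given here, the series so far offers only the limit of > 300000 nM in this assay, at which 3 of the 3 values shown sit, and no number for any compound.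

Compound 4 `Nc1nc(NCc2ccccc2)c2ncn(/C=C3/CC3(CO)CO)c2n1` has benzylamino in place of allyloxy on an aromatic carbon with the rest of the structure shared with compound 2. Among the compounds with values here, three measured steps bear on this change, all made on the saturated chain carbon of the group bound through oxygen. Neither a step that the two limits leave unreadable from compound 1 to compound 2 nor a step that the two limits leave unreadable from compound 1 to compound 3 has a size that can be carried over. The same holds for a step that the two limits leave unreadable from compound 2 to compound 3 which brings in the phenyl. Within the data shown here, no measured step puts a nitrogen in this place.

In this assay the expected a number no higher from compound 2 to compound 4 (the limit leaves the size open) is none beyond the scatter, and any number that does appear is expected to fall on the lower side of the limit. For compound 4 the half-maximal cytotoxic concentration is estimated at 300000 nM with an expected range from 100000 nM to 300000 nM and a report as a limit again is the likeliest outcome.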

Compound 4, half-maximal cytotoxic concentration: > 300000 nM
Compound 4 was reported as a limit (the forecaster's own chance of this, stated with the estimate: 70%); the middle value lies on the limit itself.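

In this assay compound 4 gives > 300000 nM, a limit of the assay and not a number. The steps to compound 4 from compound 1, compound 2 and compound 3 therefore cannot be read: the limit of > 300000 nM in this assay, at which 4 of the 4 values shown sit. The compounds shown leave open how benzylamino, allyloxy, benzyloxy and 2,2,2-trifluoroethoxy compare in this place, with no number yet on which to rank them.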